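The compounds below may be only part of what the source reports. "The series", "measured", "known", "first", "only" and "open" are said of these compounds alone.

Working notes on the series. In an ADME assay (liver) for metabolic stability, with Liver microsome (Homo sapiens) as the target, read by LC-MS, using microsomes, with a stated time of 30 min, tested at 4 uM (a lower number here means that less of the compound is left, a higher number that more of the compound is left), compound 1 `COCCn1c(-c2ccccc2Cl)nc2c(N3CCN(C(C)=O)CC3)nc(C)nc21` stands at 35% and compound 2 `COCCn1c(-c2ccccc2Cl)nc2c(N3CCN4C(=O)CCC4C3)nc(C)nc21` stands at 32% after incubation. Compound 3 `COc1cccc(-c2nc3c(N4CCN(C)CC4)nc(C)nc3n2C2CCOCC2)c1` stands at 40% in this assay and lies within the scatter of both, so the three readings cannot be ranked.

The change to compound 4 `CCc1ccccc1-c1nc2c(N3CCN(C)CC3)nc(C)nc2n1C1CCOCC1` is 2-ethylphenyl in place of 3-methoxyphenyl on an aromatic carbon and sits on an aromatic carbon of a five-membered aromatic ring with 2 nitrogen, next to the ring atom that bears an oxan-4-yl group.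

Within the data shown here, the one measured step (a number 3 percentage points lower from compound 1 to compound 2 (within the scatter)) changes a different group, so it bears on this change only loosely. It shows one replacement on the core that moved the reading by no more than the scatter. Among the measured compounds shown here, no measured step replaces the 3-methoxyphenyl group, so the data give no size or direction for this change.

The expectation therefore starts from compound 3 at 40% and assumes no step beyond the scatter in this assay while keeping the range wide. The estimated change is a number 4 percentage points lower from compound 3 to compound 4 (within the scatter) and is expected to stay within the scatter. For compound 4 the estimate is 36% with an expected range from 18% to 55% at this stage.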

Compound 4, percent of the compound remaining: 33%
Compound 4: the middle estimate sits 3 percentage points above what was measured; the measured number falls inside the stated range.
By their numbers in this assay, from the lowest: compounds 2, 4, 1 and 3 (each within the scatter of the next).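

In this assay, among these compounds, the exchange of 3-methoxyphenyl for 2-ethylphenyl on an aromatic carbon of the five-membered aromatic ring with 2 nitrogen gives a number 7 percentage points lower from compound 3 to compound 4 (within the scatter), the first step read at this position. Between these two groups, the reading does not separate a substituent counted with a hydrogen-bond acceptor and oxygen from an all-carbon one, even though the substituent's place on the phenyl ring and its name both differ, so this one step gives no sign that the position matters for the compound left after incubation. Nothing available offers an explanation for the size of this step, and no supporting measurement bears on it.

On these data alone, it remains open whether a pyridine ring, or a phenyl ring carrying a carboxylic acid or an amine, at this same position would produce a step beyond the scatter in this assay. As far as these compounds go, it is also open whether replacing the neighbouring oxan-4-yl group with a longer chain would change the reading, or would alter how the 2-ethylphenyl and 3-methoxyphenyl groups compare.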